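Cap variation on a nitro-chromene hydroxamate-free HDAC6 series

The compounds below may be only part of what the source reports. "The series", "measured", "known", "first", "only" and "open" are said of these compounds alone.

Measured compounds:
compound 1 `CCOc1cc(NC(=O)CCCCCC(=O)Nc2cc(-c3ccccc3)ccc2N)cc2c1OCC([N+](=O)[O-])=C2` — 28%
compound 2 `CCOc1cc(NC(=O)CCCCC(=O)Nc2cc(-c3ccc(C)s3)ccc2N)cc2c1OCC([N+](=O)[O-])=C2` — 8%

In an assay on isolated protein for inhibition of protein deacetylase HDAC6 (Homo sapiens), read by fluorescence, with stated times of 10 min and 30 min, tested at 10 uM (on this read-out lower numbers stand for less inhibition and higher numbers for more inhibition at the one concentration tested (going by the name of the read-out)), compound 1 gives 28%, the highest of the two numbers shown. In this assay compound 2 gives 8%; compound 1 sits a good way above it, a gap beyond the scatter. Among the measured compounds shown here, compound 2 differs from compound 1 in more than one place, so the two values show only that compound 1 reads higher, not which change carries the difference.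

Compound 3 `CCOc1cc(NC(=O)CCCCCC(=O)Nc2ccccc2N)cc2c1OCC([N+](=O)[O-])=C2` has not yet been measured. It differs from compound 1 in one place: hydrogen in place of phenyl on an aromatic carbon. For the measured compounds named here, no single-point step between measured compounds is available to anchor this change. The expectation is a modest fall in this assay, with the step of a number 10 percentage points lower from compound 1 to compound 3 (within the scatter) expected to be small and near the edge of the scatter, since compound 1 itself reads only 28%. For compound 3 the estimate is 18%, with a range from 5% to 35%.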

Compound 3, a percentage reported as inhibition, at one concentration (the size of the read-out at that concentration, not a potency): 57%
Compound 3: middle estimate off by 39 percentage points, on the low side; the whole stated range lies below it.
By their numbers in this assay, from the lowest: compound 2; then compound 1; then compound 3.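

Among the compounds shown here, with the cap and chain held constant, hydrogen in place of phenyl on an aromatic carbon, para to an amino group, gives in this assay a number 29 percentage points higher from compound 1 to compound 3 (beyond the scatter) and is the first single-place comparison. At this position, the phenyl is therefore not required for inhibition at the one concentration tested, and in this pair the unsubstituted carbon gives the higher reading. Nothing available explains the step, which stands here as an observation on one pair of compounds.

On these data alone, whether a methyl group or a methoxy group on this carbon would read closer to hydrogen or to phenyl remains open. Also open, as far as these compounds go, is whether the same exchange would give a step of similar size on a longer chain, since a single pair cannot show how far the result extends.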